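The source may hold more compounds than are shown below. What is called first, only, known or untested is meant among the compounds shown, and "the series" means these compounds.

Working notes on the series. For the measured compounds named here, in a functional assay on A549 cells (Homo sapiens) for antiproliferative activity, read by sulforhodamine B assay, with a stated time of 48 h (on this read-out lower numbers stand for stronger inhibition and higher numbers for weaker inhibition), compound 2 (`COc1cccc(C=C(C(=O)/C=C/c2cccc(OC)c2OC)C(=O)/C=C/c2cccc(OC)c2OC)c1OC`) gives 320 nM, the higher of the two numbers so far, while compound 1 (`COc1cc(C=C(C(=O)/C=C/c2cccc(OC)c2OC)C(=O)/C=C/c2cccc(OC)c2OC)ccc1O`) gives 130 nM. The next change leads to compound 3 (`COc1cccc(/C=C/C(=O)C(=Cc2ccc(O)c(F)c2)C(=O)/C=C/c2cccc(OC)c2OC)c1OC`): 3-fluoro-4-hydroxyphenyl in place of 2,3-dimethoxyphenyl on a double-bonded chain carbon bound to a double-bonded chain carbon. In words, this is 3-fluoro-4-hydroxyphenyl in place of 2,3-dimethoxyphenyl on a double-bonded chain carbon bound to a double-bonded chain carbon. Going by the values given here, one measured step bears on it: a 2.5-fold higher number from compound 1 to compound 2 (0.39 log units; beyond the scatter), modest but beyond the scatter, at the same place. There, 2,3-dimethoxyphenyl replaced 4-hydroxy-3-methoxyphenyl. Read in reverse, that step points to a lower number in this assay once a 4-hydroxy-bearing phenyl returns, though no measured step covers the fluoro group. The expected change is of similar modest size, a 2.5-fold lower number from compound 2 to compound 3 (0.39 log units; beyond the scatter). For compound 3 the estimate is 130 nM, with an expected range of 45 nM to 380 nM.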

Compound 3, half-maximal inhibitory concentration: 200 nM
Compound 3: the middle estimate sits 1.5-fold (0.19 log units) below what was measured, within the range that was stated.
By their numbers in this assay, from the lowest: compounds 1, 3 and 2 (each within the scatter of the next, the first and the last beyond it).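

Fluoro in place of methoxy on an aromatic carbon gives a 1.5-fold higher number from compound 1 to compound 3 (0.19 log units; within the scatter) in this assay, the first step at this position that keeps the hydroxyl group, and it leaves compound 1 and compound 3 unseparated. The change from 2,3-dimethoxyphenyl to 3-fluoro-4-hydroxyphenyl gives a 1.6-fold lower number from compound 2 to compound 3 (0.20 log units; within the scatter), so, unlike the earlier step between 4-hydroxy-3-methoxyphenyl and 2,3-dimethoxyphenyl, it does not separate its pair, and compound 3 cannot be ranked against either neighbour. No measurement shown explains these results.

Whether the hydroxyl group itself matters stays open, since every step shown changes other groups on the ring with it or keeps it in place. An amine or a carboxylic acid at this place, or chloro in place of fluoro, would test how far the position accepts other groups.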